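Swapping the bromophenyl end for a pyridyl ring

A few compounds are considered here, and "the series" means these few. Any claim that something is new, unique, unknown or untested is made for them only; others in the source may bear on it.

Of the compounds shown here, three sharing one dienone core have been measured in a functional assay on HeLa cells (Homo sapiens) for cytotoxicity, read by sulforhodamine B assay, with a stated time of 48 h; a lower number here means a stronger inhibitor, a higher number a weaker inhibitor. Compound 1 `CC1=C(/C=C/C(=O)/C=C/c2ccc(Br)cc2)C(C)(C)CCC1` gives 88800 nM. Compound 2 `CC1=C(/C=C/C(=O)/C=C/c2ccccc2[N+](=O)[O-])C(C)(C)CCC1` gives 36100 nM, and compound 3 `COc1cc(/C=C/C(=O)/C=C/C2=C(C)CCCC2(C)C)cc(OC)c1OC` gives 73200 nM. Among these three numbers, compound 1 stands at the highest; its gap to compound 3 lies within the scatter, while its gap to compound 2 lies beyond it. Within the data shown here, no pair among them differs in only one place, so no single step can be read from them.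

Compound 4 `CC1=C(/C=C/C(=O)/C=C/c2cccnc2)C(C)(C)CCC1` differs from compound 1 in one place: pyridin-3-yl in place of 4-bromophenyl on a double-bonded chain carbon bound to a double-bonded chain carbon. Among the measured compounds shown here, no measured step covers this change, so its direction can only be guessed from the spread of the three aryl variants, none of which moves far from the others. The step from compound 1 to compound 4 is therefore expected to be small, most likely none beyond the scatter, with a slight lean toward a higher number. Compound 4 is estimated at 100000 nM, within a range from 40000 nM to 250000 nM, which corresponds to an expected step of a 1.1-fold higher number from compound 1 to compound 4 (0.05 log units; within the scatter).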

Compound 4, half-maximal inhibitory concentration: 17400 nM
Compound 4: middle estimate off by 5.7-fold (0.76 log units), on the high side; the whole stated range lies above it.
By their numbers in this assay, from the lowest: compound 4; then compound 2; then compounds 3 and 1 (each within the scatter of the next).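

In this assay, pyridin-3-yl in place of 4-bromophenyl on a double-bonded chain carbon bound to a double-bonded chain carbon gives a 5.1-fold lower number from compound 1 to compound 4 (0.71 log units; beyond the scatter), a step beyond the scatter. Among these compounds, this shows that a single change at this place can move the number measurably, which the earlier compounds could not show, as no pair among them differed in only one place. Nothing available here accounts for the size or direction of this step.

The compounds shown leave open whether the step follows from the ring nitrogen entering or the bromine leaving, and a plain phenyl ring at this place would separate the two. On these data alone, it also remains open how an amine or a carboxylic acid on the phenyl ring would read here.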